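The source may hold more compounds than are shown below. What is called first, only, known or untested is meant among the compounds shown, and "the series" means these compounds.

Measured so far:
compound 1 `COc1cc(-c2ccnc3cc(-c4ccc(F)cc4)nn23)cc(OC)c1OC` gives 1280 nM in a functional assay on MCF7 cells (Homo sapiens) for inhibition, read by CCK-8 assay, with a stated time of 48 h; on this read-out higher numbers stand for weaker inhibition and lower numbers for stronger inhibition
compound 2 `COc1cc(-c2ccnc3cc(-c4ccc5c(ccn5C)c4)nn23)cc(OC)c1OC` gives 3 nM
compound 3 `COc1cc(-c2ccnc3cc(-c4ccc(N(C)C)cc4)nn23)cc(OC)c1OC` gives 44 nM

Compound 1 gives the highest number of the three: the steps of a 430-fold lower number from compound 1 to compound 2 (2.63 log units; beyond the scatter) and a 29-fold lower number from compound 1 to compound 3 (1.46 log units; beyond the scatter) both lead to far lower numbers, and the step of a 15-fold higher number from compound 2 to compound 3 (1.17 log units; beyond the scatter) separates those two replacements from each other. Compound 4 `COc1cc(-c2ccnc3cc(-c4cccc(C)c4)nn23)cc(OC)c1OC` differs from compound 1 in one place: 3-methylphenyl in place of 4-fluorophenyl on an aromatic carbon. Going by the values given here, no measured step tries this change; the two steps that start from compound 1 swap in different groups, so they show only that this group can move the number a great deal, not what a 3-methylphenyl does. For compound 4 a step ranging from no change beyond the scatter to a modest lowering is expected, that is a 1.8-fold lower number from compound 1 to compound 4 (0.26 log units; within the scatter). Compound 4 is therefore estimated at 700 nM, between 150 nM and 3000 nM.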

Compound 4, half-maximal inhibitory concentration: 1080 nM
Compound 4: the middle estimate sits 1.5-fold (0.19 log units) below what was measured; low and high end bracket the measured number.
By their numbers in this assay, from the lowest: compound 2; then compound 3; then compounds 4 and 1 (each within the scatter of the next).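

Replacing 4-fluorophenyl with 3-methylphenyl gives a 1.2-fold lower number from compound 1 to compound 4 (0.07 log units; within the scatter), so at this position on the shared core these two groups, each a single carbon-only ring, cannot be told apart. The large gaps appear only against the two groups containing nitrogen, with a 25-fold higher number from compound 3 to compound 4 (1.39 log units; beyond the scatter) and a 360-fold higher number from compound 2 to compound 4 (2.56 log units; beyond the scatter), which places both nitrogen-bearing groups well apart from 3-methylphenyl. Nothing measured here explains these differences. On these data alone, it remains open whether a 4-aminophenyl group, with its simple amine, would also give a low number, and whether the indole group needs its methyl on nitrogen.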